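Ring replacement at the aromatic nitrogen of the core

The source may report more compounds than this note shows. Statements on the series, on what has been measured and on what is new or still open speak of the compounds shown alone.

compound 1 `Cc1cc(NC(=O)Cn2nnc(-c3ccccc3)n2)n(C2CCCCC2)n1` — 96 nM
compound 2 `Cc1cc(NC(=O)Cn2nnc(-c3ccccc3)n2)n(C2CCCC2)n1` — 163 nM

In an assay on HEK293 cells for activation of Kir3.1/Kir3.2 (Homo sapiens), read by thallium flux (a higher number here means that more compound is needed for the effect, a lower number that less compound is needed), compound 1 gives 96 nM and compound 2 gives 163 nM. Going by the values given here, compound 2 carries the higher of the two numbers, but the only measured step, a 1.7-fold higher number from compound 1 to compound 2 (0.23 log units; within the scatter), stays within the scatter. Compound 3 `Cc1cc(NC(=O)Cn2nnc(-c3ccccc3)n2)n(C2CCS(=O)(=O)C2)n1` differs from compound 2 in one place: 1,1-dioxothiolan-3-yl in place of cyclopentyl on an aromatic nitrogen. Among the compounds with values here, no measured step covers a change of this kind; the single step shows only that swapping one carbon ring for another moved little. The step from compound 2 to compound 3 is expected to be a 1.8-fold higher number from compound 2 to compound 3 (0.26 log units; within the scatter), with wide uncertainty. Compound 3 is estimated at 300 nM, between 80 nM and 1500 nM.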

Compound 3, half-maximal effective concentration: 1030 nM
For compound 3 the middle estimate is 3.4-fold (0.54 log units) below the measured one; the measured number falls inside the stated range.
By their numbers in this assay, from the lowest: compounds 1 and 2 (each within the scatter of the next); then compound 3.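

On the aromatic nitrogen, the ring swap now has a measurable cost: in this assay 1,1-dioxothiolan-3-yl gives a 6.3-fold higher number from compound 2 to compound 3 (0.80 log units; beyond the scatter) and, set against cyclohexyl, an 11-fold higher number from compound 1 to compound 3 (1.03 log units; beyond the scatter) as the larger step. The position therefore does not accept every non-aromatic ring alike, although cyclohexyl and cyclopentyl remain within the scatter of each other. No measured evidence here accounts for the loss.

Still open, as far as these compounds go, is whether oxolan-3-yl or an amine such as piperidin-4-yl on this nitrogen would track cyclopentyl or 1,1-dioxothiolan-3-yl.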